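This account rests on a few compounds, and the source may have more. Where it says the series, first, only, none or still open, it means among the compounds named here.

Going by the values given here, compound 1 `Cc1ccc(-c2ccccc2S(=O)(=O)N2CCC(N3CCC(C)CC3)CC2)cc1` is the only member of the series with a numerical reading in a functional assay on DLD-1 cells (Homo sapiens) for antiproliferative activity, read by CellTiter-Glo, with a stated time of 72 h; a higher number here means a weaker inhibitor, a lower number a stronger inhibitor: compound 1 gives 366 nM. Compound 2 `Cc1cc(C)c(S(=O)(=O)N2CCC(c3ccccc3)CC2)c(C)c1` returns a limit in this assay rather than a number, the reading for compound 2 being > 5000 nM. One of the two values shown thus sits at the limit of > 5000 nM in this assay, at which 1 of the 2 values shown sits. Among the compounds with values here, compound 1 therefore stands alone as the only numbered point, and no step between measured compounds can be drawn from what is in hand.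

Compound 3 `COc1ccc(-c2ccccc2S(=O)(=O)N2CCC(N3CCC(C)CC3)CC2)cc1` is not yet measured. It differs from compound 1 by methoxy in place of methyl on an aromatic carbon, the rest of the shared core being unchanged. Within the data shown here, with no measured step to rest on, the expected step is a 1.1-fold higher number from compound 1 to compound 3 (0.04 log units; within the scatter), a shift that should stay within the usual scatter rather than go beyond it in either direction. Compound 3 is accordingly estimated at 400 nM in this assay, with a range from 150 nM to 1100 nM.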

Compound 3, half-maximal inhibitory concentration: 1000 nM
The estimate for compound 3 lay 2.5-fold (0.40 log units) below the measured number, within the range that was stated.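

Going by these compounds alone, the change from 4-methylphenyl to 4-methoxyphenyl gives the first measured step: in this assay there is a 2.7-fold higher number from compound 1 to compound 3 (0.44 log units; beyond the scatter), so this aromatic carbon, para to a large group, does not tolerate the exchange without a measurable shift. The step is modest, and compound 3 still gives a numerical reading of 1000 nM, so the methoxy group leaves measurable antiproliferative activity in place on the shared core. No measured property among the compounds shown bears on why the number rises with this exchange.

A single pair cannot separate the effect of the entering oxygen from that of the extra heavy atom, and a hydroxyl, an ethyl group or a chlorine atom on the same aromatic carbon would be needed to compare with the methyl and methoxy readings. Within the data shown here, also open is whether the same exchange gives a step of similar size when another part of the shared core is changed, as no second matched pair is available.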